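A few compounds are considered here, and "the series" means these few. Any claim that something is new, unique, unknown or untested is made for them only; others in the source may bear on it.

Measured compounds:
Compound 1 `O=C1c2cccc3c2c(cc2c4ccccc4oc32)C(=O)N1CN1CCNCC1`: 580 nM
Compound 2 `CCCCN1C(=O)c2cccc3c2c(cc2c4ccccc4sc32)C1=O`: 740 nM

Of the compounds shown here, two have been tested so far in a functional assay on P388 cells (Mus musculus) for cytotoxicity; a lower number here means a stronger inhibitor, a higher number a weaker inhibitor. Compound 1 gives 580 nM, and compound 2 gives 740 nM. Compound 2 has the highest of the two numbers in this assay, but its nearest neighbour, compound 1, lies within the usual scatter of it, so the two values cannot be told apart. Within the data shown here, compound 1 and compound 2 also differ in more than one place, so no single step is drawn between them.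

The next compound, compound 3 `O=C1c2cccc3c2c(cc2c4ccccc4sc32)C(=O)N1CN1CCNCC1`, is made from compound 2 by one change: piperazin-1-yl in place of propyl on a saturated chain carbon bound to an amide-type nitrogen in a ring. The group that enters is the same group that compound 1 carries in the same place, and compound 1 sits within the scatter of compound 2 in this assay. With only these two numbers to go on, no step beyond the scatter is expected from the change. Compound 3 is therefore estimated at 550 nM in this assay, with a likely range from 200 nM to 1500 nM. This corresponds to an expected step of a 1.3-fold lower number from compound 2 to compound 3 (0.13 log units; within the scatter), small and within the scatter.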

Compound 3, half-maximal inhibitory concentration: 72400 nM
Compound 3: the middle estimate sits 130-fold (2.12 log units) below what was measured; measured number outside the range, above it.
By their numbers in this assay, from the lowest: compounds 1 and 2 (each within the scatter of the next); then compound 3.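

In this assay, putting piperazin-1-yl in place of propyl on a saturated chain carbon bound to an amide-type nitrogen in a ring is far from a neutral swap: it gives a 98-fold higher number from compound 2 to compound 3 (1.99 log units; beyond the scatter) and leaves compound 3 a much weaker inhibitor, so this position is sensitive to what it carries. Compound 1 holds the same piperazin-1-yl group on a different core, yet compound 1 gives 580 nM and compound 3 gives 72400 nM in this assay, so the group's effect in this place cannot be carried over from one core to the other. No measurement is available that explains the large loss or the gap between these two cores.

On these data alone, what a morpholin-4-yl or a 4-methylpiperazin-1-yl group would give in this place on the core of compound 3 remains open, and such a comparison could show whether the loss follows the whole ring or the hydrogen on its nitrogen. Also open, as far as these compounds go, is whether a dimethylamino group on a longer chain would keep the strength of compound 2 or follow compound 3.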